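The source may report more compounds than this note shows. Statements on the series, on what has been measured and on what is new or still open speak of the compounds shown alone.

Compound 1 `OC[C@H]1O[C@@H](n2cnc3c(NCc4ccc(Br)cc4)ncnc32)[C@H](O)[C@@H]1O`: > 166000 nM
Compound 2 `COc1ccc(CNc2ncnc3c2ncn3[C@@H]2O[C@H](CO)[C@@H](O)[C@H]2O)c(OC)c1`: "not determined" (no result reported)

In a functional assay on B16 cells (Mus musculus) for antiproliferative activity, with a stated time of 72 h (a lower number here means a stronger inhibitor, a higher number a weaker inhibitor), compound 1 gives only a limit of the assay, > 166000 nM. Within the data shown here, compound 2 carries no result in this assay, "not determined" (no result reported), so it stands without a number; the one other value shown is the limit of > 166000 nM in this assay, at which 1 of the 2 values shown sits. Compound 3, `OC[C@H]1O[C@@H](n2cnc3c(NCc4ccc(F)cc4F)ncnc32)[C@H](O)[C@@H]1O`, differs from compound 2 by 2,4-difluorophenyl in place of 2,4-dimethoxyphenyl on a saturated chain carbon bound to a nitrogen on an aromatic ring. With no number for compound 2, no step size in this assay can be laid out from it, and no direction beyond the scatter is claimed. Compound 3 is expected to be weak in this assay, estimated near 120000 nM, between 20000 nM and 400000 nM.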

Compound 3, half-maximal inhibitory concentration: > 166000 nM
Compound 3: only a limit was reported (the forecaster's own chance of this, stated with the estimate: 60%); middle value at least 1.3-fold (0.14 log units) away from the limit.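

Neither compound 1 nor compound 3 gives a number, and compound 2 has no result, so no step among them can be read: the limit of > 166000 nM in this assay, at which 2 of the 3 values shown sit.

The compounds shown leave open whether 4-bromophenyl, 2,4-difluorophenyl or 2,4-dimethoxyphenyl on the shared core gives a numerical potency in this assay.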